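A few compounds are considered here, and "the series" means these few. Any claim that something is new, unique, unknown or untested is made for them only; others in the source may bear on it.

Measured in a functional assay on A-375 cells (Homo sapiens) for cytotoxicity, read by CCK-8 assay, with a stated time of 16 h; on this read-out higher numbers stand for weaker inhibition and lower numbers for stronger inhibition:
Compound 1 `COc1ccc(C2=[N+]3C(=Nc4c(-c5ccccc5)c5c(n4[B-]3(F)F)-c3ccc(OCC(=O)N[C@@H](CCC(=O)O)C(=O)O)cc3CC5)C(c3ccccc3)=C2I)cc1`: > 250000 nM
Compound 2 `COc1ccc2c(c1)CCc1c(-c3ccccc3)c3n(c1-2)[B-](F)(F)[N+]1=C(c2ccc(OCC(=O)O)cc2)C(I)=C(c2ccccc2)C1=N3`: > 50000 nM

Neither entry is a true number, so the data contain no exact potency to build on. Compound 2 has only a limit in this assay, > 50000 nM. Compound 3 `COc1ccc2c(c1)CCc1c(-c3ccccc3)c3n(c1-2)[B-](F)(F)[N+]1=C(c2ccc(OCC(=O)N[C@@H](CCC(=O)O)C(=O)O)cc2)C(I)=C(c2ccccc2)C1=N3` is made from compound 2 by one change: (1,3-dicarboxypropyl)amino in place of hydroxy on a carbonyl carbon. Put another way, carboxy becomes (1,3-dicarboxypropyl)carbamoyl.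

Among the measured compounds shown here, no measured pair in this small set isolates that change, so any forecast is uncertain. The best guide is compound 1, which also carries the (1,3-dicarboxypropyl)amino group. Compound 1 likewise has only a limit, > 250000 nM. On that basis, a step toward weaker inhibition, or no measurable change at all, is expected, and a step that the limit leaves unreadable from compound 2 to compound 3 is the estimated size. Compound 3 will most likely be reported as a limit too. For compound 3 the estimated value is 250000 nM, with an expected range from 60000 nM to 600000 nM.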

Compound 3, half-maximal inhibitory concentration in the A-375 assay: > 250000 nM
Compound 3: only a limit was reported; the forecaster's own chance of this, stated with the estimate: 85%; the middle value sits exactly at the limit.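

In the A-375 assay, compound 2 gives > 50000 nM, which is a limit, not a true number. In the A-375 assay, compound 3 gives > 250000 nM, which is also a limit, not a true number. Among the compounds shown here, no step between them can be read. The compounds shown leave open how strongly either compound inhibits these cells, and whether (1,3-dicarboxypropyl)amino in place of hydroxy changes that at all. In a physicochemical assay for lipophilicity (a lower number here means a more polar compound, a higher number a more lipophilic compound), compound 2 gives 0.92 and compound 3 gives -0.71. In the physicochemical assay, this is a number 1.63 log units lower from compound 2 to compound 3 (beyond the scatter).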